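A few compounds are considered here, and "the series" means these few. Any claim that something is new, unique, unknown or untested is made for them only; others in the source may bear on it.

Compound 1, `COC(=O)[C@@]1(C)CCC=C2[C@@H]1CC[C@@H](C)[C@]2(C)Cc1c(C)[nH]c2ccc(C)cc12`, in a functional assay on HBL-100 cells (Homo sapiens) for inhibition, read by sulforhodamine B assay, with a stated time of 48 h (on this read-out lower numbers stand for stronger inhibition of growth and higher numbers for weaker inhibition of growth), gives 25000 nM.
Compound 2, `COC(=O)[C@@]1(C)CCC=C2[C@@H]1CC[C@@H](C)[C@]2(C)Cc1c(C)[nH]c2ccc(Br)cc12`, in this assay gives 15000 nM.
Compound 3, `COC(=O)[C@@]1(C)CC[C@@H]2C3=C1CC[C@@H](C)[C@]3(C)C[C@@H]1c3cc(C)ccc3N[C@H]21`, in this assay gives 15000 nM.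

Compound 1 and compound 2 share one core and differ in a single place, (bromo in place of methyl on an aromatic carbon). This change gave a 1.7-fold lower number from compound 1 to compound 2 (0.22 log units; within the scatter), so the two numbers cannot be told apart. Compound 3 is built on a different core; the difference between the two cores is not broken down here. Its value and that of compound 2 show no difference at the digits given.

Compound 4, `COC(=O)[C@@]1(C)CC[C@@H]2C3=C1CC[C@@H](C)[C@]3(C)C[C@@H]1c3cc(Br)ccc3N[C@H]21`, has not yet been measured. It differs from compound 3 by bromo in place of methyl on an aromatic carbon. The place is described in the same words except that the ring carrying the group is part of a fused or bridged system of five rings rather than two, so this is the same kind of change as that from compound 1 to compound 2, not the same change. On that basis a step of a 1.5-fold lower number from compound 3 to compound 4 (0.18 log units; within the scatter) is expected, resting on the step of a 1.7-fold lower number from compound 1 to compound 2 (0.22 log units; within the scatter) seen in this assay. For compound 4 the estimated value is 10000 nM, expected between 5000 nM and 30000 nM.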

Compound 4, concentration for 50% growth inhibition: 34000 nM
Estimate against measurement, compound 4: 3.4-fold (0.53 log units) below, outside the stated range (above it).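

In this assay, bromo in place of methyl on an aromatic carbon gave a 2.3-fold higher number from compound 3 to compound 4 (0.36 log units; beyond the scatter), a modest step towards weaker inhibition of growth on this core. Set beside the earlier pair, this shows that the change does not carry over from one core to the other with a fixed size or direction: the same change on two cores in this assay, a 1.7-fold lower number (0.22 log units; within the scatter) from compound 1 to compound 2 and a 2.3-fold higher number (0.36 log units; beyond the scatter) from compound 3 to compound 4, 3.8-fold (0.58 log units) apart, beyond the scatter of two such steps. Among these compounds, a step read on the core of compound 1 is therefore a poor guide to the same kind of change on the core of compound 3, but with only one pair on each core, this does not show which feature of the cores separates the two steps, or how any other change would carry over.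

The compounds shown leave open how a chloro, a methoxy or an amine at this place would compare on the two cores. They also leave open whether a carboxylic acid in place of the methyl ester would alter growth inhibition on either core.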